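The source may report more compounds than this note shows. Statements on the series, on what has been measured and on what is new or still open speak of the compounds shown alone.

Working notes on the series. In a functional assay (aorta) for inhibition, with Rattus norvegicus as the target (on this read-out lower numbers stand for stronger inhibition and higher numbers for weaker inhibition), compound 1 `Nc1nsc(-c2ccc(N3CCN(c4cccc(C(F)(F)F)c4)CC3)nn2)n1` gives 20 nM. Among the compounds with values here, compound 2 `Cc1nsc(-c2ccc(N3CCN(c4cccc(F)c4)CC3)nn2)n1` gives 6 nM, the lower of the two numbers so far, and the gap to compound 1 lies beyond the usual scatter. The next compound to be tested is compound 3 `Cc1nsc(-c2ccc(N3CCN(c4cccc(N)c4)CC3)nn2)n1`, which differs from compound 2 in one place: amino in place of fluoro on an aromatic carbon, meta to a large group, or 3-fluorophenyl to 3-aminophenyl (amino in place of fluoro on an aromatic carbon). Within the data shown here, no measured pair shows this change, so the expectation rests on little. In this assay the expected 2.5-fold higher number from compound 2 to compound 3 (0.40 log units; beyond the scatter) is a modest one towards weaker inhibition, only slightly beyond the scatter. Compound 3 is estimated at 15 nM, with an expected range from 4 nM to 60 nM.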

Compound 3, half-maximal inhibitory concentration: > 100 nM
Compound 3: a limit, no number; the forecaster's own chance of this, stated with the estimate: 3%; middle value at least 6.6-fold (0.82 log units) from the limit.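

In this assay, compound 3 stands at a limit of the assay, > 100 nM, and not at a number. Amino in place of fluoro on an aromatic carbon, meta to a large group, gives an at least 16-fold higher number from compound 2 to compound 3 (1.22 log units; beyond the scatter), the first single-place step in the series. This position is therefore sensitive to an exchange of one heavy atom for one heavy atom, a sensitivity that compound 1 and compound 2 could not show, as they differ in more than one place.

The compounds shown do not tell whether the step belongs to amino alone or would also appear with hydroxy, methoxy or dimethylamino on the same carbon. The full size of the step also stays open: the limit of > 100 nM in this assay, at which 1 of the 3 values shown sits.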